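The compounds below may be only part of what the source reports. "The series", "measured", "known", "first", "only" and "open" are said of these compounds alone.

Measured in a functional assay on NCI-H661 cells (Homo sapiens) for antiproliferative activity, read by MTT assay, with a stated time of 72 h; a lower number here means a stronger inhibitor, a higher number a weaker inhibitor:
- Compound 1 `COc1ccc(-c2noc(CCCCCCC(=O)NO)n2)cc1`: 20400 nM
- Compound 2 `Nc1ccccc1NC(=O)CCCCCCc1nc(-c2ccccc2)no1`: 960 nM
- Compound 3 `O=C(CCCCCCc1nc(-c2ccccc2)no1)C(F)(F)F`: 520 nM

Compound 3 and compound 2 lie within the scatter of each other, so neither can be ranked ahead. Compound 1, at 20400 nM, has a much higher number than compound 3, at 520 nM, and so is the weaker inhibitor.

Compound 4 `O=C(CCCCCCc1nc(-c2ccc(C(F)(F)F)cc2)no1)C(F)(F)F` keeps compound 3 unchanged except for one edit: trifluoromethyl in place of hydrogen on an aromatic carbon.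

For the measured compounds named here, the only measured step, a 1.8-fold lower number from compound 2 to compound 3 (0.27 log units; within the scatter), changes the group on a carbonyl carbon and leaves the aromatic ring untouched. Going by the values given here, it therefore offers only indirect guidance, and no measured step tests a substituent on that ring on its own. With no evidence for a direction, no change beyond the scatter is expected in this assay. The estimated step is a 1.0-fold lower number from compound 3 to compound 4 (0.02 log units; within the scatter). For compound 4 the expected value is 500 nM, with an estimated range from 150 nM to 1700 nM.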

Compound 4, half-maximal inhibitory concentration: 6390 nM
Compound 4: the middle estimate sits 13-fold (1.11 log units) below what was measured; the whole stated range lies below it.
By their numbers in this assay, from the lowest: compounds 3 and 2 (each within the scatter of the next); then compound 4; then compound 1.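

In this assay, for the compounds shown here, the edit gives a 12-fold higher number from compound 3 to compound 4 (1.09 log units; beyond the scatter) and is the only step so far that lies beyond the scatter. It is also the first direct test of a substituent on this aromatic ring, and it shows that the ring carbon para to a large group is not indifferent to what sits there. Adding trifluoromethyl at this position gives a clearly weaker inhibitor, and no information at hand explains this loss.

With a single substituent tested here, the compounds shown leave open whether the loss belongs to trifluoromethyl itself or would follow any group at this carbon. A fluorine atom, a methyl group or an amine at the same position of compound 3 would help separate those two readings.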